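Swapping the aryl group on a urea-type side chain

The source may report more compounds than this note shows. Statements on the series, on what has been measured and on what is new or still open speak of the compounds shown alone.

Compound 1 `C=C[C@]1(C)C[C@@H](OC(=O)CNC(=O)Nc2ccc(OC)cc2)[C@]2(C)[C@H](C)CC[C@]3(CCC(=O)[C@H]32)[C@@H](C)[C@@H]1O` carries a 4-methoxyphenyl group on an amide-type nitrogen of its side chain. In a functional assay on MCF7 cells (Homo sapiens) for inhibition, read by MTT assay, with a stated time of 72 h (a higher number here means a weaker inhibitor, a lower number a stronger inhibitor), compound 1 gives > 10000 nM, which is a limit of the measurement rather than a number. Compound 2 `C=C[C@]1(C)C[C@@H](OC(=O)CNC(=O)Nc2cccc(Br)c2)[C@]2(C)[C@H](C)CC[C@]3(CCC(=O)[C@H]32)[C@@H](C)[C@@H]1O` also returns only a limit, > 10000 nM, in this assay. Compound 3 `C=C[C@]1(C)C[C@@H](OC(=O)CNC(=O)NC(=O)c2cccc(F)c2)[C@]2(C)[C@H](C)CC[C@]3(CCC(=O)[C@H]32)[C@@H](C)[C@@H]1O` likewise stops at the limit > 10000 nM in this assay. The steps between them, a step that the two limits leave unreadable from compound 1 to compound 2, a step that the two limits leave unreadable from compound 1 to compound 3 and a step that the two limits leave unreadable from compound 2 to compound 3, therefore cannot be sized.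

Compound 4 `C=C[C@]1(C)C[C@@H](OC(=O)CNC(=O)Nc2ccc(F)cc2F)[C@]2(C)[C@H](C)CC[C@]3(CCC(=O)[C@H]32)[C@@H](C)[C@@H]1O` differs from compound 1 by 2,4-difluorophenyl in place of 4-methoxyphenyl on an amide-type nitrogen. Among the compounds with values here, every measured change on this nitrogen left the value at the same place, as the limit of > 10000 nM in this assay, at which 3 of the 3 values shown sit, records, so no step of readable size supports a shift in either direction. The expected step that the limit leaves unreadable from compound 1 to compound 4 is therefore set close to no change. For compound 4 in this assay the estimate is 15000 nM, with a range from 7000 nM to 40000 nM, most likely again reported only as a limit.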

Compound 4, half-maximal inhibitory concentration: > 10000 nM
Compound 4 ended at the assay's limit; the forecaster's own chance of this, stated with the estimate: 85%; the middle value does not contradict the limit.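

Compound 4 gives > 10000 nM in this assay, again a limit rather than a number, so its steps from compound 1, compound 2 and compound 3 cannot be read. The compounds shown leave open whether any group on this amide-type nitrogen gives a readable value, as all stop at one place: the limit of > 10000 nM in this assay, at which 4 of the 4 values shown sit.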